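Trading Methoxymethyl for Hydrogen on an Aromatic Oxygen

A few compounds are considered here, and "the series" means these few. Any claim that something is new, unique, unknown or untested is made for them only; others in the source may bear on it.

Compound 1 `COCOc1cc(/C=C/C(=O)OCC(=O)Nc2ccc(OC)cc2)ccc1OCc1ccccc1`: in a functional assay on PC-3 cells (Homo sapiens) for cytotoxicity, read by MTT assay, with a stated time of 72 h (on this read-out lower numbers stand for stronger inhibition and higher numbers for weaker inhibition), compound 1 gives > 200000 nM, a limit of the assay and not a number.
Compound 2 `COCOc1cc(/C=C/C(=O)OCC(=O)Nc2ccc(Cl)cc2)ccc1OCc1ccccc1`: in this assay compound 2 gives > 200000 nM, also only a limit.
Compound 3 `COCOc1cc(/C=C/C(=O)OCC(=O)NN2CCOCC2)ccc1OCc1ccccc1`: in this assay compound 3 gives > 200000 nM, again a limit.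

Compound 1 therefore stands only at a limit. Because the limit of > 200000 nM in this assay, at which 3 of the 3 values shown sit, is where every value sits, the steps a step that the two limits leave unreadable from compound 1 to compound 2, a step that the two limits leave unreadable from compound 1 to compound 3 and a step that the two limits leave unreadable from compound 2 to compound 3 cannot be read in size or direction. Compound 4 `COc1ccc(NC(=O)COC(=O)/C=C/c2ccc(OCc3ccccc3)c(O)c2)cc1` differs from compound 1 by hydrogen in place of methoxymethyl on an oxygen on an aromatic ring. Among the compounds with values here, no measured step touches this oxygen, so none bears directly on the change. With all measured compounds at the limit, compound 4 is expected to remain near it, the step of an at least 1.3-fold lower number from compound 1 to compound 4 (0.12 log units; that floor lies within the scatter) being an estimate of no change beyond the scatter. The estimate for compound 4 is 150000 nM, ranging from 30000 nM to 600000 nM.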

Compound 4, half-maximal inhibitory concentration: > 200000 nM
Compound 4 gave a limit, no number; the forecaster's own chance of this, stated with the estimate: 60%; middle value at least 1.3-fold (0.12 log units) from the limit.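

Compound 1 and compound 4 both stand only at a limit, and the step between them cannot be read in size or direction. From the compounds shown here alone, whether any change to the shared core can give a real number in this assay stays open.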